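Para substituent and plasma half-life in the triazene series

The source may report more compounds than this note shows. Statements on the series, on what has been measured and on what is new or still open speak of the compounds shown alone.

The series shares one core, shown by compound 3 `Cc1ccc(/N=N/N(C)C(=O)CCc2ccc(O)cc2)cc1`, in which the group on the aromatic carbon para to the large group is varied. In an ADME assay on a cell-free system (plasma, Homo sapiens) for metabolic stability, read by HPLC (on this read-out higher numbers stand for a longer-lived compound and lower numbers for a shorter-lived compound), compound 3 gives 8.7 h, the highest of the three numbers. Compound 2 `CN(/N=N/c1ccc(Br)cc1)C(=O)CCc1ccc(O)cc1` gives 8.3 h, and the step of a 1.0-fold higher number from compound 2 to compound 3 (0.02 log units; within the scatter) is within the scatter, so the two are not separated. Compound 1 `CN(/N=N/c1ccc(C#N)cc1)C(=O)CCc1ccc(O)cc1` gives 2.99 h; the steps of a 2.8-fold higher number from compound 1 to compound 2 (0.44 log units; beyond the scatter) and a 2.9-fold higher number from compound 1 to compound 3 (0.46 log units; beyond the scatter) show that cyano at this position goes with a shorter-lived compound than bromo or methyl.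

Compound 4 `CCOC(=O)c1ccc(/N=N/N(C)C(=O)CCc2ccc(O)cc2)cc1` carries ethoxycarbonyl in place of methyl on an aromatic carbon. Among the compounds with values here, no measured step involves ethoxycarbonyl, so the nearest guide is the one substituent change that moved the number beyond the scatter, the cyano case of compound 1 at 2.99 h against methyl in compound 3 at 8.7 h. Ethoxycarbonyl is a group of five heavy atoms with two hydrogen-bond acceptors and a double bond outside the ring, unlike methyl or bromo; a modest downward step in this assay is expected, a 2.2-fold lower number from compound 3 to compound 4 (0.34 log units; beyond the scatter), with wide uncertainty. Compound 4 is therefore estimated at 4 h, expected to fall between 1.5 h and 9.5 h.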

Compound 4, half-life in the Homo sapiens assay: 6.57 h
For compound 4 the middle estimate is 1.6-fold (0.22 log units) below the measured one; the measured number falls inside the stated range.
By their numbers in the Homo sapiens assay, from the lowest: compound 1; then compounds 4, 2 and 3 (each within the scatter of the next).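

Notes on the para position: in the Homo sapiens assay, ethoxycarbonyl, with 5 heavy atoms and 2 hydrogen-bond acceptors, is not separated from the smaller groups, as a 1.3-fold lower number from compound 3 to compound 4 (0.12 log units; within the scatter) and a 1.3-fold lower number from compound 2 to compound 4 (0.10 log units; within the scatter) both show, while a 2.2-fold higher number from compound 1 to compound 4 (0.34 log units; beyond the scatter) keeps it apart from cyano. Among the four compounds, cyano therefore stands alone at the short end, and on this aromatic carbon, para to a large group, the added heavy atoms, acceptors and double bond of ethoxycarbonyl do not go with a step beyond the scatter from methyl or bromo. Nothing available bears on why cyano differs from the other three groups.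

In a physicochemical assay for lipophilicity, read by HPLC, in phosphate buffer, measured as octanol-water partition, with a stated time of 30 min (on this read-out higher numbers stand for higher lipophilicity and lower numbers for lower lipophilicity), compound 3 is recorded as "not determined" (no result reported) and compound 4 as "not determined" (no result reported), so the steps on this read-out cannot be read. The compounds shown leave open whether a carboxylic acid, an amine or a longer ester chain on this aromatic carbon would stay with methyl, bromo and ethoxycarbonyl or fall with cyano in the Homo sapiens assay.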